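A few compounds are considered here, and "the series" means these few. Any claim that something is new, unique, unknown or untested is made for them only; others in the source may bear on it.

Compound 2 `O=C(COc1ccc2cc(/C=C3/SC(=O)NC3=O)ccc2c1)Nc1ccc(Cl)c(Cl)c1` reaches only a limit in an assay on isolated protein for inhibition of histone deacetylase 8 (Homo sapiens), with a stated time of 1 h; on this read-out lower numbers stand for stronger inhibition and higher numbers for weaker inhibition: for compound 2 the value of > 50000 nM marks the edge of what this assay can report (the limit of > 50000 nM in this assay, at which 1 of the 2 values shown sits). Its neighbour compound 1 `Cc1ccc(NC(=O)COc2ccc3cc(/C=C4/SC(=O)NC4=O)ccc3c2)cc1` gives 9000 nM, and the change of an at least 5.5-fold higher number from compound 1 to compound 2 (0.74 log units; beyond the scatter) shows that the dichlorinated ring weakened inhibition. Compound 3 `O=C(COc1ccc2cc(/C=C3/SC(=O)NC3=O)ccc2c1)Nc1cccc(Cl)c1` reverses part of that: hydrogen in place of chloro on an aromatic carbon, so 3,4-dichlorophenyl becomes 3-chlorophenyl. Since compound 1 showed the better number, compound 3 is expected to move back toward it, a step of an at least 2.0-fold lower number from compound 2 to compound 3 (0.30 log units; that floor lies within the scatter). The estimate for compound 3 is 25000 nM, between 8000 nM and 70000 nM.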

Compound 3, half-maximal inhibitory concentration: > 50000 nM
Compound 3: a limit, no number; the forecaster's own chance of this, stated with the estimate: 35%; middle value at least 2.0-fold (0.30 log units) from the limit.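

Taking away the chloro para to a large group does not restore a readable number: in this assay compound 3 also stays at a limit, > 50000 nM. Exchanging 4-methylphenyl for 3-chlorophenyl gives an at least 5.5-fold higher number from compound 1 to compound 3 (0.74 log units; beyond the scatter), so the loss seen with 3,4-dichlorophenyl does not need both chloro groups. The step between compound 2 and compound 3 cannot be read, because both rest at the same edge: the limit of > 50000 nM in this assay, at which 2 of the 3 values shown sit.

Still open, going by these compounds, is whether a plain phenyl, or a methoxy or an amine on the ring, would match or improve on compound 1 at 9000 nM.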